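This account rests on a few compounds, and the source may have more. Where it says the series, first, only, none or still open, it means among the compounds named here.

In an in vitro assay on COS-1 cells for inhibition of sodium-dependent dopamine transporter (Homo sapiens) (on this read-out lower numbers stand for stronger inhibition and higher numbers for weaker inhibition), compound 1 `COC(=O)C1=C(c2ccccc2)C2CCC1C2` gives 646000 nM, compound 2 `COC(=O)C1=C(c2ccc(-c3ccccc3)cc2)C2CCC1C2` gives 603000 nM, and compound 3 `COC(=O)C1=C(c2ccc(Cl)cc2)C2CCC1C2` gives 25100 nM, the lowest of the three numbers. The step of a 26-fold lower number from compound 1 to compound 3 (1.41 log units; beyond the scatter) and the step of a 24-fold lower number from compound 2 to compound 3 (1.38 log units; beyond the scatter) both set compound 3 apart as the strongest inhibitor of the measured set, whereas a 1.1-fold lower number from compound 1 to compound 2 (0.03 log units; within the scatter) shows nothing beyond the scatter. Compound 4 `COC(=O)C1=C(c2ccc(Cl)c(Cl)c2)C2CCC1C2` differs from compound 3 in one place: chloro in place of hydrogen on an aromatic carbon. For the measured compounds named here, only the two chloro steps bear on this change; both were large, but each introduced the first chloro group, and no measured step adds a second one. A further lowering in this assay, smaller than those steps, is expected, a 3.6-fold lower number from compound 3 to compound 4 (0.55 log units; beyond the scatter). Compound 4 is therefore estimated at 7000 nM, with a range from 2000 nM to 25000 nM.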

Compound 4, inhibition constant: 6760 nM
Estimate against measurement, compound 4: 1.0-fold (0.02 log units) above; low and high end bracket the measured number.
By their numbers in this assay, from the lowest: compound 4; then compound 3; then compounds 2 and 1 (each within the scatter of the next).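

A second chloro group still lowers the number in this assay, with a 3.7-fold lower number from compound 3 to compound 4 (0.57 log units; beyond the scatter), so the effect of chloro substitution does not end with the first one. The position ortho to a chloro group and meta to a large group tolerates the change, although this step is smaller than a 26-fold lower number from compound 1 to compound 3 (1.41 log units; beyond the scatter). No supporting data explain the further lowering.

Going by these compounds, whether fluoro, bromo, methyl or trifluoromethyl at this position would give a similar step remains open. Also open, on these data alone, is whether this chloro group would lower the number without the existing chloro group.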